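A Methyl Added to the Benzyl Ring of Compound 3

A few compounds are considered here, and "the series" means these few. Any claim that something is new, unique, unknown or untested is made for them only; others in the source may bear on it.

Measured in an assay for inhibition of Amine oxidase [flavin-containing] B (Rattus norvegicus); on this read-out lower numbers stand for stronger inhibition and higher numbers for weaker inhibition:
compound 1 `Cc1ccc(COc2ccc(-c3nn(CCC#N)c(=S)o3)cc2)cc1` gives 400 nM
compound 2 `CC(C#N)Cn1nc(-c2ccc(OCc3ccccc3)cc2)oc1=O` gives 2400 nM
compound 3 `N#CCCN1N=C(c2ccc(OCc3ccccc3)cc2)OCC1=O` gives 18 nM

Compound 3 stands lowest of the three numbers, and both compound 1 and compound 2 lie beyond the scatter above it. Compound 4 `Cc1cccc(COc2ccc(C3=NN(CCC#N)C(=O)CO3)cc2)c1` differs from compound 3 by methyl in place of hydrogen on an aromatic carbon. For the measured compounds named here, no measured pair here shows this change on a shared core; compound 1 also carries a methyl on its benzyl ring, but its core is another one, so its value says nothing about this step. The step from compound 3 to compound 4 in this assay is expected to be a 1.1-fold higher number from compound 3 to compound 4 (0.05 log units; within the scatter), not beyond the scatter. Compound 4 is therefore estimated at 20 nM, between 6 nM and 70 nM.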

Compound 4, half-maximal inhibitory concentration: 31 nM
Compound 4: middle estimate off by 1.6-fold (0.19 log units), on the low side; the range from low to high includes it.
By their numbers in this assay, from the lowest: compounds 3 and 4 (each within the scatter of the next); then compound 1; then compound 2.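

In this assay, for the compounds shown here, methyl in place of hydrogen on this aromatic carbon gives a 1.7-fold higher number from compound 3 to compound 4 (0.24 log units; within the scatter), the first reading of this change on a shared core. On this core, benzyl and 3-methylbenzyl therefore cannot be told apart, so this position carries a methyl with no difference beyond the scatter. Nothing available bears on why this is so.

From the compounds shown here alone, whether a methoxy group or a chlorine atom at this place would read the same remains open. So does whether a methyl on another carbon of this ring would do so.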